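The source may report more compounds than this note shows. Statements on the series, on what has been measured and on what is new or still open speak of the compounds shown alone.

Series notes on the basic amine side chain compounds.

Compound 1 `COc1cccc(Oc2ccc3c(NCCCNCc4cccc(OC)c4O)ccnc3c2)c1` gives 9.28 in a physicochemical assay for acid dissociation. Compound 2 `COc1cccc(CNCCCNc2ccnc3cc(Cc4cccc(C(F)(F)F)c4)ccc23)c1O` gives 9.47. Compound 3 `COc1ccc(F)cc1CNCCCNc1ccnc2cc(Cc3cccc(C(F)(F)F)c3)ccc12` gives 9.47, level with compound 2 at the digits printed; together they stand highest of the three numbers, with compound 1 nearest below them, although the gap to compound 1 is within the scatter, so no order among the three is claimed.

The two measured steps are both small: a number 0.19 log units higher from compound 1 to compound 2 (within the scatter), and no change at the digits printed from compound 2 to compound 3 (within the scatter). The first of these changed the group on the aromatic carbon of the shared core, the second the group on the chain carbon bound to the amine nitrogen.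

Compound 4 `COc1ccc(F)cc1CNCCCNc1ccnc2cc(-c3ccc(C(F)(F)F)cc3)ccc12` differs from compound 3 as follows: 4-(trifluoromethyl)phenyl in place of 3-(trifluoromethyl)benzyl on an aromatic carbon. This change sits at the same aromatic carbon of the core that was varied from compound 1 to compound 2, where the step stayed within the scatter. The site that carries the proton in question is not touched. The expected step is therefore none beyond the scatter, a number 0.02 log units lower from compound 3 to compound 4 (within the scatter).

For compound 4 the estimated value in this assay is 9.45, expected to lie between 9.2 and 9.7.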

Compound 4, acid dissociation constant: 9.47
Compound 4: the middle estimate sits 0.02 log units below what was measured; measured number inside the range.
By their numbers in this assay, from the lowest: compounds 1, 2, 3 and 4 (each within the scatter of the next).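

In this assay the exchange of 3-(trifluoromethyl)benzyl for 4-(trifluoromethyl)phenyl on this aromatic carbon of the core gives no change at the digits printed from compound 3 to compound 4 (within the scatter), so a second type of exchange at this carbon now stays within the scatter, this time with the phenyl ring in place of a benzyl group and the trifluoromethyl name changing from 3 to 4. Among compounds 1 to 4, both exchanges read at this carbon lie within the scatter, and no compound shown goes against that. No measurement shown offers an explanation for this reading.

Every group shown at this carbon carries a six-membered aromatic ring of carbon only, so the reading with an amine or a carboxylic acid there remains open. Also open, going by these compounds, is how a longer chain joining the two amine nitrogens would read in this assay.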